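This account rests on a few compounds, and the source may have more. Where it says the series, first, only, none or still open, it means among the compounds named here.

Measured so far:

Compound 1, `CNC(=O)CCCCCCCn1nc(-c2cnc3[nH]ccc3c2)c2c(N)ncnc21`, gives 17400 nM.
Compound 2, `Nc1ncnc2c1c(-c1cnc3[nH]ccc3c1)nn2CCCCCCCCC(=O)NO`, gives 18900 nM.
Compound 3, `Nc1nc2cc(-c3nn(CCCCCCCCC(=O)NO)c4ncnc(N)c34)ccc2o1`, gives only a limit of the assay, > 100000 nM.

All three were tested in a functional assay on Bel-7402 cells (Homo sapiens) for inhibition, read by MTT assay, with a stated time of 72 h; a lower number here means a stronger inhibitor, a higher number a weaker inhibitor. Compound 1 and compound 2 share a core and differ only at the far end of the chain: methylcarbamoyl in place of (hydroxycarbamoyl)methyl on a saturated chain carbon, seven bonds along the chain from an aromatic nitrogen. The step of a 1.1-fold lower number from compound 2 to compound 1 (0.04 log units; within the scatter), so the two values show no difference that can be told apart. Compound 2 and compound 3 differ in the ring group carried on the shared core: a group of 10 heavy atoms (7 carbon, 2 nitrogen, 1 oxygen; one five-membered aromatic ring with 2 hetero atoms, one six-membered aromatic ring of carbon only) in place of a group of 9 heavy atoms (7 carbon, 2 nitrogen; one five-membered aromatic ring with 1 hetero atom, one six-membered aromatic ring with 1 hetero atom), on an aromatic carbon. The step of an at least 5.2-fold higher number from compound 2 to compound 3 (0.72 log units; beyond the scatter). For compound 3 only a limit is known: the limit of > 100000 nM in this assay, at which 1 of the 3 values shown sits.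

Compound 4, `CNC(=O)CCCCCCCn1nc(-c2ccc3oc(N)nc3c2)c2c(N)ncnc21`, has not yet been measured. It stands to compound 3 exactly as compound 1 stands to compound 2, with the same change at the same place: methylcarbamoyl in place of (hydroxycarbamoyl)methyl on a saturated chain carbon, seven bonds along the chain from an aromatic nitrogen. Because a 1.1-fold lower number from compound 2 to compound 1 (0.04 log units; within the scatter) lay within the scatter, the same change on the core of compound 3 is expected to give a step that the limit leaves unreadable from compound 3 to compound 4. Compound 4 is therefore expected to land at about 150000 nM in this assay, with a likely range from 60000 nM to 400000 nM, and most probably this assay will again report only a limit rather than a number.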

Compound 4, half-maximal inhibitory concentration: 13200 nM
For compound 4 the middle estimate is 11-fold (1.06 log units) above the measured one, outside the stated range (below it).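

In this assay, the change from (hydroxycarbamoyl)methyl to methylcarbamoyl gives an at least 7.5-fold lower number from compound 3 to compound 4 (0.87 log units; beyond the scatter), so it does not carry over from one core to the other at the same size: the same change on two cores in this assay, a 1.1-fold lower number (0.04 log units; within the scatter) from compound 2 to compound 1 and an at least 7.5-fold lower number (0.87 log units; beyond the scatter) from compound 3 to compound 4, at least 6.9-fold (0.84 log units) apart, beyond the scatter of two such steps. The swap of ring group reads differently at the two chain ends as well, with a 1.3-fold lower number from compound 1 to compound 4 (0.12 log units; within the scatter), so in these four compounds the ring group makes a readable difference only with the (hydroxycarbamoyl)methyl end: the same change on two cores in this assay, an at least 5.2-fold higher number (0.72 log units; beyond the scatter) from compound 2 to compound 3 and a 1.3-fold lower number (0.12 log units; within the scatter) from compound 1 to compound 4, at least 6.9-fold (0.84 log units) apart, beyond the scatter of two such steps. Compound 3 gives only a limit of the assay, > 100000 nM, and not a number, and these compounds show neither the true size of the gap between the steps nor why it arises.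

Still open, from the compounds shown here alone, is whether the same dependence on the core appears with other ring groups on the shared core, such as a plain phenyl, or with other chain ends, such as a carboxylic acid or a primary amide. A longer or shorter chain between the core and the end group also remains to be seen, as does any reading of these compounds on a second cell line.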